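A few compounds are considered here, and "the series" means these few. Any claim that something is new, unique, unknown or untested is made for them only; others in the source may bear on it.

Measured compounds:
compound 1 `CN(C)/N=N\c1ccnc2cc(Br)ccc12` with -8.9%
compound 2 `CN(C)/N=N\c1ccnc2cc(Cl)ccc12` with -22.6%
compound 3 `CN(C)/N=N\c1ccnc2c(Br)cccc12` with -3.3%

All three were run in a toxicity assay on the whole organism (P388 cells) for cytotoxicity, with Mus musculus as the target, with a stated time of 9 days, at a dose of 40 mg/kg by the intraperitoneal route; on this read-out higher numbers stand for a weaker effect at the one dose given and lower numbers for a stronger effect. Among them compound 2 stands lowest; the nearest is compound 1, which lies above it beyond the scatter, and compound 3 lies higher still, also beyond the scatter. Compound 1 and compound 3 themselves differ by only a few points, and their two values show no separation worth reading.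

The next compound, compound 4 `CN(C)/N=N\c1ccnc2cc(I)ccc12`, has not yet been measured in this assay. Its change from compound 2 is iodo in place of chloro on an aromatic carbon.

Among the compounds with values here, one measured step bears on this change: the swap of one halogen for another at the same place, a number 13.7 percentage points lower from compound 1 to compound 2 (beyond the scatter). That step went down when the larger halogen gave way to the smaller one. Going the other way, from chloro to the still larger iodo, the same size of step in the opposite direction seems the nearest guide, though only one such step is known and it rests on a single pair.

Compound 4 is therefore expected to sit above compound 2, a step of a number 15.6 percentage points higher from compound 2 to compound 4 (beyond the scatter), with an estimate of -7% and a range from -25% to 12%.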

Compound 4, a percentage reported as activity, at one dose (the size of the read-out at that dose, not a potency): 5.7%
Compound 4: the middle estimate sits 12.7 percentage points below what was measured; the range from low to high includes it.
By their numbers in this assay, from the lowest: compound 2; then compounds 1, 3 and 4 (each within the scatter of the next, the first and the last beyond it).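

In this assay, the iodo group extends what had been a single halogen swap at this position, with a number 28.3 percentage points higher from compound 2 to compound 4 (beyond the scatter) and a number 14.6 percentage points higher from compound 1 to compound 4 (beyond the scatter). The three halogens at this place now fall in one order, chloro, then bromo, then iodo, with each step beyond the scatter, so the direction seen in the one earlier pair holds across a second swap and the read-out runs in step with the halogen series among these three compounds. Nothing available explains why the read-out follows this order, and no outside measurement on these compounds bears on the result.

The compounds shown leave open whether a group other than a halogen, such as a methoxy group or an amine, would fall in line with this order at the same place, and whether chloro and iodo at the place held by bromo in compound 3 would order themselves the same way. Each compound also appears at one dose only, so the order describes a stronger or weaker effect at that dose and nothing beyond it.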